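This account rests on a few compounds, and the source may have more. Where it says the series, first, only, none or still open, it means among the compounds named here.

Measured so far:
compound 1, `CC(=O)c1ccc(NC(=O)CN(C(=O)c2ccccc2)S(=O)(=O)c2ccc([N+](=O)[O-])cc2)cc1` — 20.7%
compound 2, `CC(=O)c1ccc(NC(=O)C(CC(C)C)N(C(=O)c2ccccc2)S(=O)(=O)c2ccc([N+](=O)[O-])cc2)cc1` — 71%
compound 3, `CC(=O)c1ccc(NC(=O)C(C(C)C)N(C(=O)c2ccccc2)S(=O)(=O)c2ccc([N+](=O)[O-])cc2)cc1` — 27.2%

All three numbers come from a functional assay for inhibition, read by spectrophotometry, with a stated time of 20 min, tested at 4 mg/mL; on this read-out higher numbers stand for a stronger effect at the one concentration tested and lower numbers for a weaker effect. Compound 3 stands second highest of the three. Its nearest neighbour is compound 1: the step of a number 6.5 percentage points higher from compound 1 to compound 3 (within the scatter) lies within the scatter, so the two cannot be ordered. Its furthest neighbour is compound 2: the step of a number 43.8 percentage points lower from compound 2 to compound 3 (beyond the scatter) is large, as is the step of a number 50.3 percentage points higher from compound 1 to compound 2 (beyond the scatter); both of these concern the substituent on the saturated chain carbon bound to the amide-type nitrogen and the carbonyl carbon, and nothing else in the series varies.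

Compound 4, `CC(=O)c1ccc(NC(=O)C(C(C)C)N(C(=O)c2ccccc2)S(=O)(=O)c2ccccc2)cc1`, keeps the isopropyl of compound 3 and differs from it elsewhere: hydrogen in place of nitro on an aromatic carbon. Going by the values given here, no measured step touches the aryl sulfonyl part, so the measured steps give no direct bearing on this change; they only show that the series can move by large amounts when the chain substituent is altered, which is not what changes here. The expectation is therefore a step in this assay of about a number 0.2 percentage points lower from compound 3 to compound 4 (within the scatter) from compound 3 to compound 4, i.e. none beyond the scatter, with wide uncertainty. For compound 4 the estimate in this assay is 27%, with a range from 8% to 50%.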

Compound 4, a percentage reported as inhibition, at one concentration (the size of the read-out at that concentration, not a potency): 52.2%
Estimate against measurement, compound 4: 25.2 percentage points below, and the stated range ends below it.
By their numbers in this assay, from the lowest: compounds 1 and 3 (each within the scatter of the next); then compound 4; then compound 2.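

Until this pair, only the substituent on the chain carbon had been seen to move the read-out; with the isopropyl held fixed, the change from (4-nitrophenyl)sulfonyl to phenylsulfonyl in this assay gives a number 25 percentage points higher from compound 3 to compound 4 (beyond the scatter), so the aryl sulfonyl part is also a position that responds. The nitro on this aromatic carbon, para to a large group, is therefore not needed for the effect at the one concentration tested in the isopropyl compounds, and hydrogen in its place gives the higher number, though this rests on a single pair. No measurement shown here bears on why the number moves at this position.

Still open is whether the same exchange of nitro for hydrogen would carry over to the isobutyl of compound 2 or to the unsubstituted chain carbon of compound 1, as the only pair shown has the isopropyl. Also open, from the compounds shown here alone, is how an amine, a methoxy group or a carboxylic acid on that same aromatic carbon would read.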